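Swapping Fluoro for a Chloroacetamide: Expected Cytotoxicity

The source may hold more compounds than are shown below. What is called first, only, known or untested is meant among the compounds shown, and "the series" means these compounds.

Measured compounds:
compound 1, `Fc1ccc(-c2nc3cc(C(F)(F)F)ccc3[nH]2)cc1`, gives 22000 nM in an ADME assay on MT4 cells (Homo sapiens) for cytotoxicity, read by MTT assay, with a stated time of 96 h; a lower number here means that less compound is tolerated, a higher number that more compound is tolerated.
compound 2, `Cn1c(-c2ccc(NC(=O)CN3CCCCC3)cc2)nc2cc(C(F)(F)F)ccc21`, gives 9000 nM in this assay.
compound 3, `COc1ccc(-c2nc3cc(C(C)=O)ccc3[nH]2)c(OC)c1OC`, reaches only a limit of this assay, > 100000 nM.

Of the two numbers that are numbers rather than limits, compound 1 holds the higher one. Its nearest neighbour is compound 2, whose number is lower, and that gap lies beyond the usual scatter of this assay. Compound 3 stands apart with the limit of > 100000 nM in this assay, at which 1 of the 3 values shown sits.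

The compound not yet measured is compound 4, `O=C(CCl)Nc1ccc(-c2nc3cc(C(F)(F)F)ccc3[nH]2)cc1`. It differs from compound 1 in a single place: ((chloromethyl)carbonyl)amino in place of fluoro on an aromatic carbon. Among the measured compounds shown here, no measured pair covers this exact change, so the expectation rests on what the numbers show. Compound 2 also carries an amide-bearing substituent on the shared core, and compound 2 gives 9000 nM, which sits below compound 1. On that basis, compound 4 is expected to be tolerated less than compound 1, and the step of a 2.8-fold lower number from compound 1 to compound 4 (0.44 log units; beyond the scatter) is expected to lie beyond the scatter rather than within it. Compound 4 is therefore estimated at 8000 nM in this assay, with a range from 2500 nM to 30000 nM.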

Compound 4, half-maximal cytotoxic concentration: 5000 nM
Beside the measured number, compound 4's estimate is 1.6-fold (0.20 log units) above it; the range from low to high includes it.
By their numbers in this assay, from the lowest: compounds 4 and 2 (each within the scatter of the next); then compound 1. At a limit, above all of these: compound 3.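

At this position, on an aromatic carbon para to a large group, the change now has a measured pair: in this assay, ((chloromethyl)carbonyl)amino in place of fluoro gives a 4.4-fold lower number from compound 1 to compound 4 (0.64 log units; beyond the scatter), so less compound is tolerated. The earlier compounds shown here offered no pair that differed in one place, so they showed no step at this position, and this one shows that the position responds to this exchange of a single fluorine for a chain of 5 heavy atoms carrying 1 hydrogen-bond donor and 1 hydrogen-bond acceptor. Nothing measured here accounts for the size or direction of that step.

The compounds shown leave open which part of the entering group goes with the step, and a plain acetylamino group, with methyl in place of chloromethyl, or a simple amine at the same place would separate the chlorine from the amide. Going by these compounds, with a single pair carrying this change, the step is also known only on the core of compound 1, and whether it holds on another core remains open.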